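Moving the Chlorine on the Triazole Aryl Ring

The source may hold more compounds than are shown below. What is called first, only, known or untested is meant among the compounds shown, and "the series" means these compounds.

Compound 1 `COc1cc(O)c(C(=O)/C=C/c2ccc(OC)c(OCc3cn(-c4ccccc4Cl)nn3)c2)c(OC)c1` in an ADME assay on Huh-7 cells (Homo sapiens) for cytotoxicity, read by MTT assay, with a stated time of 72 h (on this read-out lower numbers stand for higher toxicity in this test and higher numbers for lower toxicity in this test), gives > 100 ug/mL, a limit of the test.
Compound 2 `COc1cc(O)c(C(=O)/C=C/c2ccc(OC)c(OCc3cn(-c4ccc(F)cc4F)nn3)c2)c(OC)c1` in this assay gives > 100 ug/mL, a limit of the test.
Compound 3 `COc1cc(O)c(C(=O)/C=C/c2ccc(OC)c(OCc3cn(-c4ccc(F)c(Cl)c4)nn3)c2)c(OC)c1` in this assay gives > 100 ug/mL, a limit of the test.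

Compound 3 therefore stands only at a limit, not at a number. All three measured compounds sit at the same point, (the limit of > 100 ug/mL in this assay, at which 3 of the 3 values shown sit), so the steps between them cannot be read: a step that the two limits leave unreadable from compound 1 to compound 2, a step that the two limits leave unreadable from compound 1 to compound 3 and a step that the two limits leave unreadable from compound 2 to compound 3 give no size and no direction.

Compound 4 `COc1cc(O)c(C(=O)/C=C/c2ccc(OC)c(OCc3cn(-c4ccc(F)cc4Cl)nn3)c2)c(OC)c1` is the next member of the series. Its difference from compound 3 is 2-chloro-4-fluorophenyl in place of 3-chloro-4-fluorophenyl on an aromatic nitrogen. Going by the values given here, the only steps that bear on this change are those among compounds 1, 2 and 3, and each of them is unreadable. The three measured compounds show no toxicity up to the limit in this assay, and compound 4 is expected to behave the same way, with a step that the limit leaves unreadable from compound 3 to compound 4 that is expected to lie within the scatter. The estimate for compound 4 in this assay is 150 ug/mL, with a range from 70 ug/mL to 400 ug/mL, and most likely again only a limit.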

Compound 4, half-maximal cytotoxic concentration: > 100 ug/mL
Compound 4: only a limit was reported (the forecaster's own chance of this, stated with the estimate: 85%); the middle value does not contradict the limit.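

Compound 4 sits at the same limit as compounds 1, 2 and 3, so none of its steps to those compounds can be read: the limit of > 100 ug/mL in this assay, at which 4 of the 4 values shown sit.

The compounds shown leave open whether moving the chlorine or fluorine on this aryl ring changes the result in this assay once concentrations pass that limit.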